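The source may report more compounds than this note shows. Statements on the series, on what has been measured and on what is new or still open speak of the compounds shown alone.

Measured compounds, each with its value in a functional assay on PC-3 cells (Homo sapiens) for antiproliferative activity, read by MTT assay, with a stated time of 48 h; on this read-out lower numbers stand for stronger inhibition and higher numbers for weaker inhibition:

compound 1 `COc1cc(N/C=C\C(=O)c2cn(-c3ccccc3)nc2-c2ccc(F)cc2)cc(OC)c1OC` gives 4890 nM
compound 2 `COc1cc(N/C=C\C(=O)c2cn(-c3ccccc3)nc2-c2ccc(Cl)cc2)cc(OC)c1OC` gives 9980 nM
compound 3 `COc1ccc(-c2nn(-c3ccccc3)cc2C(=O)/C=C\Nc2ccc(F)cc2)cc1` gives 5730 nM

Compound 1 and compound 2 share one core and differ only by chloro in place of fluoro on an aromatic carbon. That change gives a 2.0-fold higher number from compound 1 to compound 2 (0.31 log units; beyond the scatter). Compound 3 carries a different core; the difference between the two cores is not broken down here. Against compound 1, compound 3 shows a number that differs only within the scatter, and against compound 2 likewise.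

Compound 4 `COc1ccc(-c2nn(-c3ccccc3)cc2C(=O)/C=C\Nc2ccc(Cl)cc2)cc1` is not yet measured. It differs from compound 3 by chloro in place of fluoro on an aromatic carbon. The surroundings of the place are the same in both pairs, so this is the same change as that from compound 1 to compound 2, seen once before.

For compound 4 in this assay a step of about a 1.9-fold higher number from compound 3 to compound 4 (0.28 log units; within the scatter) is expected, resting on the single earlier case, which gave a 2.0-fold higher number from compound 1 to compound 2 (0.31 log units; beyond the scatter), and on the value of compound 3, 5730 nM. Going by the values given here, with only one prior instance the spread is wide. The estimate for compound 4 is 11000 nM, between 5000 nM and 25000 nM.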

Compound 4, half-maximal inhibitory concentration: 3890 nM
Compound 4: the middle estimate sits 2.8-fold (0.45 log units) above what was measured; measured number below the stated range.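

In this assay, chloro in place of fluoro on the core of compound 3 gives a 1.5-fold lower number from compound 3 to compound 4 (0.17 log units; within the scatter), so on this core the change leaves the number within the scatter. The same change therefore does not carry over from one core to the other as a fixed step: the same change on two cores in this assay, a 2.0-fold higher number (0.31 log units; beyond the scatter) from compound 1 to compound 2 and a 1.5-fold lower number (0.17 log units; within the scatter) from compound 3 to compound 4, 3.0-fold (0.48 log units) apart, beyond the scatter of two such steps

Going by these compounds alone, with only two pairs in a single assay, this shows that a step seen on one core is a poor guide to the other, but it does not show what sets the two apart, since the halogen sits in a 4-fluorophenyl group on the core of compound 1 and in a (4-fluorophenyl)amino group on the core of compound 3, and the cores differ elsewhere too.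

The compounds shown leave open how bromo, methyl or trifluoromethyl in the same place would read on either core. They also leave open whether the two cores would again part ways with an unsubstituted phenyl or a methoxy group there.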